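The source may report more compounds than this note shows. Statements on the series, on what has been measured and on what is new or still open speak of the compounds shown alone.

Compound 1, `COc1cc2c(cc1OC)C(=O)C(CC1CCN(C(=S)Nc3ccccc3)CC1)C2`, in a functional assay on the whole organism (strain Swiss albino) with Mus musculus as the target, in the maximal electroshock model, with a stated time of 0.5 h (on this read-out higher numbers stand for an effect only at larger amounts of compound and lower numbers for an effect already at smaller amounts), gives 100 mg/kg.
Compound 2, `COc1cc2c(cc1OC)C(=O)C(CC1CCN(C(=S)Nc3cccc(C)c3)CC1)C2`, gives 300 mg/kg.
Compound 3, `COc1cc2c(cc1OC)C(=O)C(CC1CCN(C(=S)Nc3ccccc3[N+](=O)[O-])CC1)C2`, gives 100 mg/kg.

Compound 3 stands level with compound 1 at the digits reported, the two together holding the lowest numbers of the three, while there was a 3.0-fold lower number from compound 2 to compound 3 (0.48 log units; beyond the scatter). Compound 4, `COc1cc2c(cc1OC)C(=O)C(CC1CCN(C(=S)Nc3ccccc3Cl)CC1)C2`, differs from compound 3 by chloro in place of nitro on an aromatic carbon. Within the data shown here, no measured step replaces one substituent with another on this aromatic carbon; the nearest guidance is no change at the digits printed from compound 1 to compound 3 (within the scatter), showing that the nitro group brought nothing beyond the scatter, and a 3.0-fold higher number from compound 1 to compound 2 (0.48 log units; beyond the scatter), a modest shift from a small group on an aromatic carbon. The change is therefore expected to stay within the scatter, with no change at the digits printed from compound 3 to compound 4 (within the scatter). Compound 4 is estimated at 100 mg/kg, between 50 mg/kg and 300 mg/kg.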

Compound 4, minimum effective dose: 100 mg/kg
Beside the measured number, compound 4's estimate shows no gap at the digits printed; measured number inside the range.
By their numbers in this assay, from the lowest: compounds 1, 3 and 4 (each within the scatter of the next); then compound 2.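

In this assay, chloro in place of nitro on this aromatic carbon, ortho to a large group, gave no change at the digits printed from compound 3 to compound 4 (within the scatter) and chloro in place of hydrogen gave no change at the digits printed from compound 1 to compound 4 (within the scatter), so a second substituent here, with a single atom rather than three heavy atoms, also leaves the number where the unsubstituted ring has it. The change from 3-methylphenyl to 2-chlorophenyl gave a 3.0-fold lower number from compound 2 to compound 4 (0.48 log units; beyond the scatter), matching the gap the nitro compound showed. Nothing available explains why these substituents make no difference. Going by these compounds, whether an amine or a carboxylic acid on this aromatic carbon would also stay level remains open, as does whether chloro would behave like the methyl of compound 2 if it stood at that group's place.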